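Swapping the nitrophenyl for a dichlorophenyl on the core

The source may hold more compounds than are shown below. What is called first, only, known or untested is meant among the compounds shown, and "the series" means these compounds.

In a functional assay (aorta) with Oryctolagus cuniculus as the target (a lower number here means a stronger inhibitor, a higher number a weaker inhibitor), compound 2 `CC1=NC(C)=C(C(=O)OCCCN2C(=O)c3ccccc3S2(=O)=O)C(c2cccc([N+](=O)[O-])c2)/C1=C(\O)OC(C)C` gives 1 nM, the lowest of the three numbers; compound 1 `CCO/C(O)=C1\C(C)=NC(C)=C(C(=O)OCCCN2C(=O)c3ccccc3S2(=O)=O)C1c1cccc([N+](=O)[O-])c1` gives 1.9 nM, and compound 3 `CC1=NC(C)=C(C(=O)OCCCN2C(=O)c3ccccc3S2(=O)=O)C(c2cccc([N+](=O)[O-])c2)/C1=C(\O)OCC1CCCO1` gives 10.5 nM. The measured steps, a 1.9-fold lower number from compound 1 to compound 2 (0.28 log units; within the scatter), a 5.5-fold higher number from compound 1 to compound 3 (0.74 log units; beyond the scatter) and an 11-fold higher number from compound 2 to compound 3 (1.02 log units; beyond the scatter), all alter the group attached through the oxygen on an unsaturated carbon of the shared core. Compound 4 `CC1=NC(C)=C(C(=O)OCCCN2C(=O)c3ccccc3S2(=O)=O)C(c2cccc(Cl)c2Cl)/C1=C(\O)OC(C)C` instead alters the group on the saturated ring carbon: 2,3-dichlorophenyl in place of 3-nitrophenyl on a saturated ring carbon. Among the measured compounds shown here, no measured step touches this place, so the data give no direction for it. For compound 4 the expected step is a 1.2-fold higher number from compound 2 to compound 4 (0.08 log units; within the scatter), within the scatter. Compound 4 is therefore estimated at 1.2 nM in this assay, with a range from 0.3 nM to 5 nM.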

Compound 4, half-maximal inhibitory concentration: 2.1 nM
Estimate against measurement, compound 4: 1.8-fold (0.24 log units) below; measured number inside the range.
By their numbers in this assay, from the lowest: compounds 2, 1 and 4 (each within the scatter of the next, the first and the last beyond it); then compound 3.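

The group on the saturated ring carbon can be changed without a large loss: 2,3-dichlorophenyl in place of 3-nitrophenyl gives a 2.1-fold higher number from compound 2 to compound 4 (0.32 log units; beyond the scatter) in this assay, a modest step and the only one shown at this position. The 2 hydrogen-bond acceptors of 3-nitrophenyl are therefore not required for compound 4 to reach 2.1 nM in this series. No measurement available here explains the step. As far as these compounds go, it remains open whether a plain phenyl, or a phenyl carrying an amine or a carboxylic acid, would keep the number this low. Also open, from the compounds shown here alone, is whether the groups on the oxygen would rank the same alongside 2,3-dichlorophenyl.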